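The source may hold more compounds than are shown below. What is called first, only, known or untested is meant among the compounds shown, and "the series" means these compounds.

In a functional assay on A549 cells (Homo sapiens) for antiproliferative activity, read by CCK-8 assay, with a stated time of 72 h (a lower number here means a stronger inhibitor of growth, a higher number a weaker inhibitor of growth), three compounds have been measured so far. Compound 1 `CCC1C(=O)N(C)c2cnc(Nc3ccc(S(=O)(=O)NCC(C)C)cc3)nc2N1c1ccn(C)n1` gives 31600 nM, compound 2 `CC[C@@H]1C(=O)N(C)c2cnc(-n3ccc4cc(C(N)=O)ccc43)nc2N1C1CCCC1` gives 4350 nM and compound 3 `CC[C@@H]1C(=O)N(C)c2cnc(Nc3ccc(S(=O)(=O)NC4CCCC4)cc3)nc2N1C1CCCC1` gives 1150 nM. Compound 2 therefore sits in the middle, with clear gaps on both sides: its number is higher than that of compound 3 and lower than that of compound 1.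

The next compound, compound 4 `CC[C@@H]1C(=O)N(C)c2cnc(-n3ccc4cc(C(=O)NCC(C)C)ccc43)nc2N1C1CCCC1`, differs from compound 2 at a single place: isobutyl in place of hydrogen on an amide-type nitrogen. In words, this is isobutyl in place of hydrogen on an amide-type nitrogen.

Among the measured compounds shown here, no measured pair shows this change alone, so any expectation is uncertain. Compound 1 at 31600 nM and compound 3 at 1150 nM both carry an alkyl group on a sulfonamide nitrogen, yet they fall on opposite sides of compound 2, so they suggest no direction. In this assay, the estimated change is therefore small, and the expected 1.2-fold lower number from compound 2 to compound 4 (0.09 log units; within the scatter) stays within the usual scatter. The estimate for compound 4 is 3500 nM, with an expected range of 1100 nM to 11000 nM.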

Compound 4, concentration for 50% growth inhibition: 1730 nM
Compound 4: middle estimate off by 2.0-fold (0.31 log units), on the high side, within the range that was stated.
By their numbers in this assay, from the lowest: compounds 3 and 4 (each within the scatter of the next); then compound 2; then compound 1.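

In this assay, replacing the amide hydrogen with isobutyl gives a 2.5-fold lower number from compound 2 to compound 4 (0.40 log units; beyond the scatter). This is the first single change that can be read directly among these compounds, and it shows that the amide-type nitrogen can carry this branched chain with growth inhibition not lost but modestly improved. No measurement shown here accounts for the gain.

Among the compounds shown here, with only this one step, it remains open whether the gain belongs to isobutyl in particular or would also appear with a smaller group such as methyl, a longer chain such as hexyl, or a chain ending in an amine. It is also unknown whether the same change would have a similar effect on a compound with a different group elsewhere on the shared core.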